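The source may hold more compounds than are shown below. What is called first, only, known or untested is meant among the compounds shown, and "the series" means these compounds.

Compound 1 `COc1cc(-c2nnc3n2NC(c2ccco2)C(C(=O)c2cccc(Br)c2)S3)cc(OC)c1OC` gives 63900 nM.
Compound 2 `COc1cc(-c2nnc3n2NC(c2cccs2)C(C(=O)c2ccc(Cl)cc2)S3)cc(OC)c1OC` gives 32500 nM.
Compound 3 `COc1cc(-c2nnc3n2NC(c2ccco2)C(C(=O)c2ccc(C(F)(F)F)cc2)S3)cc(OC)c1OC` gives 77500 nM.

In a functional assay on PC-3 cells (Homo sapiens) for cytotoxicity, read by MTT assay, with a stated time of 48 h (on this read-out higher numbers stand for weaker inhibition and lower numbers for stronger inhibition), compound 1 stands second highest of the three numbers; compound 3 lies nearest and compound 2 furthest, and both gaps are within the scatter. Going by the values given here, the single measured step, a 1.2-fold higher number from compound 1 to compound 3 (0.08 log units; within the scatter), swaps the aryl group on the carbonyl carbon and is itself within the scatter. Compound 4 `COc1cc(-c2nnc3n2NC(c2ccco2)C(C(=O)c2ccccc2)S3)cc(OC)c1OC` differs from compound 1 thus: hydrogen in place of bromo on an aromatic carbon. Among the compounds with values here, no measured step removes a bromo from that ring, so the step from compound 1 to compound 3 is the only guide; on that basis no step beyond the scatter is expected, a 1.0-fold higher number from compound 1 to compound 4 (0.01 log units; within the scatter). Compound 4 is therefore estimated at 65000 nM, ranging from 25000 nM to 170000 nM.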

Compound 4, half-maximal inhibitory concentration: 64300 nM
Beside the measured number, compound 4's estimate is 1.0-fold (0.00 log units) above it, within the range that was stated.
By their numbers in this assay, from the lowest: compounds 2, 1, 4 and 3 (each within the scatter of the next, the first and the last beyond it).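

In this assay, hydrogen in place of bromo gives a 1.0-fold higher number from compound 1 to compound 4 (0.00 log units; within the scatter) and hydrogen in place of trifluoromethyl gives a 1.2-fold lower number from compound 3 to compound 4 (0.08 log units; within the scatter), so both steps stay within the scatter. Across compounds 1, 3 and 4, neither group on this six-membered aromatic ring separates from hydrogen. No measured evidence accounts for this result.

On these data alone, whether an amine or a carboxylic acid on this ring would give a step beyond the scatter remains open. Compound 2 differs from these compounds in more than one place, so the separate effects of its thiophene and 4-chlorophenyl groups cannot be read.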